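The source may report more compounds than this note shows. Statements on the series, on what has been measured and on what is new or still open speak of the compounds shown alone.

Measured compounds:
Compound 1 `O=C(O)Cc1sc(C(c2ccc(F)cc2)c2ccc(F)cc2)nc1-c1ccc(Cl)cc1` gives 9.7 nM in an in vitro assay on HEK385-7 cells for displacement of a labelled ligand from prostaglandin D2 receptor 2 (Homo sapiens); a lower number here means a stronger inhibitor, a higher number a weaker inhibitor.
Compound 2 `COc1ccc(C(c2ccccc2)c2nc(-c3ccc(Cl)cc3)c(CC(=O)O)s2)cc1` gives 8.4 nM.
Compound 3 `O=C(O)Cc1sc(C(c2ccccc2)c2ccc(O)cc2)nc1-c1ccc(F)cc1` gives 3.4 nM.

Compound 1 has the highest of the three numbers in this assay. Its nearest neighbour is compound 2, which sits within the usual scatter of it; its furthest is compound 3, whose lower number lies beyond the scatter. Compound 4 `Cc1cc(-c2nc(C(c3ccc(F)cc3)c3ccc(F)cc3)sc2CC(=O)O)ccn1` differs from compound 1 in one place: 2-methylpyridin-4-yl in place of 4-chlorophenyl on an aromatic carbon. For the measured compounds named here, no measured pair isolates this exchange, so its effect has to be guessed. The expected step is a small one, leaning toward a higher number, and may well stay within the scatter: a 1.5-fold higher number from compound 1 to compound 4 (0.19 log units; within the scatter). Compound 4 is therefore expected to give 15 nM in this assay, with a range from 5 nM to 45 nM.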

Compound 4, half-maximal inhibitory concentration: 3.1 nM
The estimate for compound 4 lay 4.8-fold (0.68 log units) above the measured number, and the stated range ends above it.
By their numbers in this assay, from the lowest: compounds 4 and 3 (each within the scatter of the next); then compounds 2 and 1 (each within the scatter of the next).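

At the aromatic carbon next to the ring nitrogen, 2-methylpyridin-4-yl in place of 4-chlorophenyl gives a 3.1-fold lower number from compound 1 to compound 4 (0.50 log units; beyond the scatter) in this assay. This position therefore tolerates a ring with one hetero atom and one hydrogen-bond acceptor, and compound 4 needs no chlorine there to reach this level. Nothing measured here bears on why the number falls. Whether the ring nitrogen or the methyl group accounts for the step remains open, and plain pyridin-4-yl at this position would separate the two.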